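A few compounds are considered here, and "the series" means these few. Any claim that something is new, unique, unknown or untested is made for them only; others in the source may bear on it.

Measured so far:

Compound 1, `O=C(O)CCC(=O)OCCCCCCSc1ccc([N+](=O)[O-])c2nonc12`, in a functional assay on A549 cells (Homo sapiens) for inhibition, read by MTT assay, with a stated time of 72 h (on this read-out lower numbers stand for stronger inhibition and higher numbers for weaker inhibition), compound 1 gives 3640 nM.
Compound 2, `O=C(CCC(=O)OCCCCCCSc1ccc([N+](=O)[O-])c2nonc12)Nc1ccccc1F`, compound 2 gives 2440 nM.
Compound 3, `COc1ccccc1NC(=O)CCC(=O)OCCCCCCSc1ccc([N+](=O)[O-])c2nonc12`, compound 3 gives 1870 nM.

Compound 2 sits second highest of the three numbers; its gaps to compound 3 and to compound 1 are both within the scatter. Compound 4, `O=C(CCC(=O)N1CCOCC1)OCCCCCCSc1ccc([N+](=O)[O-])c2nonc12`, differs from compound 2 in one place: morpholin-4-yl in place of (2-fluorophenyl)amino on a carbonyl carbon. Among the measured compounds shown here, the steps that bear on this change all touch the same carbonyl carbon: a 1.5-fold lower number from compound 1 to compound 2 (0.17 log units; within the scatter), a 1.9-fold lower number from compound 1 to compound 3 (0.29 log units; within the scatter) and a 1.3-fold lower number from compound 2 to compound 3 (0.12 log units; within the scatter), none of them beyond the scatter. Nothing here separates an aromatic from a non-aromatic group at that position. The expected step is therefore a 1.2-fold higher number from compound 2 to compound 4 (0.09 log units; within the scatter), a change no larger than the scatter. Compound 4 is estimated at 3000 nM, in the range 1200 nM to 7500 nM.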

Compound 4, half-maximal inhibitory concentration: 1670 nM
Estimate against measurement, compound 4: 1.8-fold (0.25 log units) above; low and high end bracket the measured number.
By their numbers in this assay, from the lowest: compounds 4, 3, 2 and 1 (each within the scatter of the next, the first and the last beyond it).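

In this assay the non-aromatic morpholin-4-yl, with no hydrogen-bond donor, stays level with the aromatic amides: a 1.5-fold lower number from compound 2 to compound 4 (0.16 log units; within the scatter) and a 1.1-fold lower number from compound 3 to compound 4 (0.05 log units; within the scatter) both lie within the scatter. Among these compounds, then, neither an aromatic ring nor an amide hydrogen on this carbonyl carbon is required to match compound 2 and compound 3. Among the compounds shown here, the first step at this position to pass the scatter, though only modestly, is a 2.2-fold lower number from compound 1 to compound 4 (0.34 log units; beyond the scatter) and no measured evidence explains it. Still open, from the compounds shown here alone, is whether an open-chain amine such as diethylamino, or a piperazin-1-yl ring, would match morpholin-4-yl here.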